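The compounds below may be only part of what the source reports. "The series", "measured", "known", "first", "only" and "open" are said of these compounds alone.

Compound 1 `CCCCSc1nc(N)nc2c1ncn2/C=C1/CC1(CO)CO` in an ADME assay on Akata cells (Homo sapiens) for cytotoxicity, with a stated time of 7 days (a lower number here means that less compound is tolerated, a higher number that more compound is tolerated), gives > 20000 nM, which is a limit of the assay rather than a number.
Compound 2 `CC(C)CSc1nc(N)nc2c1ncn2/C=C1/CC1(CO)CO` in this assay gives > 20000 nM, again a limit.
Compound 3 `Nc1nc(OCC(F)(F)F)c2ncn(/C=C3/CC3(CO)CO)c2n1` in this assay gives > 20000 nM, also a limit.

Compound 1 therefore stands at the limit of > 20000 nM in this assay, at which 3 of the 3 values shown sit, the same point at which every value shown sits. The step from compound 4 back to the measured set runs through compound 1: compound 4 `COCCOc1nc(N)nc2c1ncn2/C=C1/CC1(CO)CO` differs from it by 2-methoxyethoxy in place of butylsulfanyl on an aromatic carbon. The measured steps that bear on this position are a step that the two limits leave unreadable from compound 1 to compound 2 and a step that the two limits leave unreadable from compound 1 to compound 3, and both are unreadable, since a limit on each side leaves no size to compare. Going by the values given here, the change to compound 4 is of the same kind, an exchange of the group on that aromatic carbon, and no measured compound shows anything other than a limit there. The expectation is accordingly that compound 4 also reaches only the limit, with a step that the limit leaves unreadable from compound 1 to compound 4 that cannot be told from none. Compound 4 is thus estimated at 30000 nM, between 15000 nM and 100000 nM.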

Compound 4, half-maximal cytotoxic concentration: > 20000 nM
Compound 4 ended at the assay's limit (the forecaster's own chance of this, stated with the estimate: 85%); the middle value lies beyond the limit too.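

Going by these compounds alone, compounds 1, 2, 3 and 4 all sit at a limit of the assay rather than at a number, so no step among them can be read: the limit of > 20000 nM in this assay, at which 4 of the 4 values shown sit.
Left open is whether, in this assay, exchanging the groups among these compounds changes the result at all.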